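The compounds below may be only part of what the source reports. "The series", "measured", "known", "first", "only" and "open" are said of these compounds alone.

Compound 1, `COc1cc(C(=O)NS(=O)(=O)c2ccc3ccccc3c2)ccc1Cn1ccc2ccc(NC(=O)CC3CCCC3)cc21`: 8.3
Compound 2, `CCCCC(CC)C(=O)Nc1ccc2ccn(Cc3ccc(C(=O)C(C#N)S(=O)(=O)c4ccccc4)cc3OC)c2c1`: 8.1
Compound 3, `CCCCC(CC)C(=O)Nc1ccc2ccn(Cc3ccc(C(=O)NS(=O)(=O)c4ccccc4C)cc3OC)c2c1`: 8.9

The three measured compounds were tested in a functional assay (trachea) for antagonist activity, with Cavia porcellus as the target; on this read-out lower numbers stand for lower potency and higher numbers for higher potency (the scale is a negative logarithm). Compound 1 sits between the other two: compound 2 has a value within the scatter of its own, while compound 3 lies beyond the scatter above it. Going by the values given here, the only measured step between compounds that differ in a single place is a number 0.80 log units higher from compound 2 to compound 3 (beyond the scatter), which replaces a cyano(phenylsulfonyl)methyl group on the carbonyl carbon with a ((2-methylphenyl)sulfonyl)amino group.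

Compound 4, `COc1ccc(OC)c(S(=O)(=O)NC(=O)c2ccc(Cn3ccc4ccc(NC(=O)CC5CCCC5)cc43)c(OC)c2)c1`, has not yet been measured. It differs from compound 1 in one place: 2,5-dimethoxyphenyl in place of naphthalen-2-yl on a sulfonyl sulfur. This change keeps the acylsulfonamide linkage seen in compound 1 and compound 3 and only swaps the aryl group on the sulfonyl sulfur. Among the compounds with values here, no measured step bears directly on such a swap; the step from compound 2 to compound 3 changes the linkage itself, not the aryl group alone, so it gives no direct guide. Compound 1 and compound 3, both acylsulfonamides with different aryl groups on the sulfonyl sulfur, show values separated by more than the scatter, but they also differ elsewhere. On these numbers the expected step for compound 4 in this assay is no change at the digits printed from compound 1 to compound 4 (within the scatter), none beyond the scatter. Compound 4 is therefore estimated at 8.3, with a range from 7.7 to 8.9.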

Compound 4, negative logarithm of the antagonist equilibrium constant: 9.1
Compound 4: the middle estimate sits 0.80 log units below what was measured, outside the stated range (above it).
By their numbers in this assay, from the lowest: compounds 2 and 1 (each within the scatter of the next); then compounds 3 and 4 (each within the scatter of the next).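

In this assay, putting 2,5-dimethoxyphenyl in place of naphthalen-2-yl on a sulfonyl sulfur whose other neighbour is an amide-type nitrogen gives a number 0.80 log units higher from compound 1 to compound 4 (beyond the scatter). Going by these compounds alone, this is the first measured step confined to this aryl group, and it shows that changing this group alone, with the rest of compound 1 held fixed, can shift the number by more than the scatter. It also shows that, in this pair, the naphthalen-2-yl group with its 2 six-membered aromatic rings can be exchanged for a group with one such ring and 2 hydrogen-bond acceptors without any loss, although nothing shown explains why the number rises.

The compounds shown leave open how much of the step belongs to the two methoxy groups together, as against a plain phenyl or a phenyl carrying a single methoxy group on the same sulfonyl sulfur. They also leave open whether 2,5-dimethoxyphenyl would give a similar step when the acyl chain of compound 4 is replaced by a longer chain, or whether a pyridine ring would serve in its place.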